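Toward Lower Liver-Cell Toxicity with a Ring Swap

The source may hold more compounds than are shown below. What is called first, only, known or untested is meant among the compounds shown, and "the series" means these compounds.

In an ADME assay on HepG2 2.2.15 cells (Homo sapiens) for cytotoxicity, read by luminescence, with a stated time of 3 days (on this read-out lower numbers stand for higher toxicity in this test and higher numbers for lower toxicity in this test), compound 2 `O=C(Nc1ccc(F)c(Cl)c1)c1ccc(F)c(S(=O)(=O)N2CCCC(O)CC2)c1` gives 29000 nM, the highest number of the two measured compounds; compound 1 `O=C(Nc1ccc(F)c(Cl)c1)c1ccc(F)c(S(=O)(=O)N2CCOC[C@H](O)C2)c1` gives 19000 nM, and a 1.5-fold higher number from compound 1 to compound 2 (0.18 log units; within the scatter). As far as these compounds go, compound 3 `O=C(Nc1ccc(F)c(Cl)c1)c1ccc(F)c(S(=O)(=O)N2CCOC[C@@H](O)C2)c1` is untested in this assay. The change from compound 2 to compound 3 is 6-hydroxy-1,4-oxazepan-4-yl in place of 4-hydroxyazepan-1-yl on a sulfonyl sulfur. Among the compounds with values here, the one relevant step ran the opposite way and stayed within the scatter, so no change beyond the scatter is expected here, perhaps a slight return toward compound 1 at 19000 nM. Compound 3 is therefore estimated at 20000 nM, expected between 10000 nM and 40000 nM, which means an expected 1.5-fold lower number from compound 2 to compound 3 (0.16 log units; within the scatter).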

Compound 3, half-maximal cytotoxic concentration: 14000 nM
Compound 3: the middle estimate sits 1.4-fold (0.15 log units) above what was measured; the range from low to high includes it.
By their numbers in this assay, from the lowest: compounds 3, 1 and 2 (each within the scatter of the next, the first and the last beyond it).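

In this assay, the swap on the sulfonyl sulfur now gives a modest step beyond the scatter, a 2.1-fold lower number from compound 2 to compound 3 (0.32 log units; beyond the scatter), which the step between compound 1 and compound 2 did not. Changing only the stereocentre at a saturated ring carbon stays within the scatter, a 1.4-fold lower number from compound 1 to compound 3 (0.13 log units; within the scatter), so this pair gives no clear stereochemical preference: the fact that compounds 1 and 3 differ only in the configuration as drawn

Still open, as far as these compounds go, is how an amine in place of the hydroxy group, or a six-membered morpholine ring on the sulfonyl sulfur, would read in this assay.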